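This account rests on a few compounds, and the source may have more. Where it says the series, first, only, none or still open, it means among the compounds named here.

Working notes on the series in a functional assay on A549 cells (Homo sapiens) for antiproliferative activity, read by MTT assay, with a stated time of 24 h; a higher number here means a weaker inhibitor, a lower number a stronger inhibitor. Compound 1 `O=C(NNc1ccccc1Cl)c1ccc(NS(=O)(=O)c2cnc(O)nc2O)cc1` gives 3340 nM, and compound 2 `O=C(NNc1ccccc1F)c1ccc(NS(=O)(=O)c2cnc(O)nc2O)cc1` gives 11700 nM. Compound 3 `Cc1ccccc1NNC(=O)c1cccc(NS(=O)(=O)c2cnc(O)nc2O)c1` gives 14200 nM, within the scatter of compound 2 and beyond the scatter of compound 1, on the weaker side. Compound 4 `Cc1cccc(NNC(=O)c2cccc(NS(=O)(=O)c3cnc(O)nc3O)c2)c1` differs from it by 3-methylphenyl in place of 2-methylphenyl on an amine nitrogen. For the measured compounds named here, the only measured step, a 3.5-fold higher number from compound 1 to compound 2 (0.54 log units; beyond the scatter), exchanges chloro for fluoro rather than moving a methyl, so it bears only indirectly. A step of no more than that modest size is expected, and the data do not settle its direction. The estimated step is a 1.2-fold lower number from compound 3 to compound 4 (0.07 log units; within the scatter). Compound 4 is expected at 12000 nM, within a range of 5000 nM to 28000 nM.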

Compound 4, half-maximal inhibitory concentration: > 20000 nM
Compound 4 ended at the assay's limit; the forecaster's own chance of this, stated with the estimate: 3%; middle value at least 1.6-fold (0.22 log units) away from the limit.
By their numbers in this assay, from the lowest: compound 1; then compounds 2 and 3 (each within the scatter of the next). At a limit, above all of these: compound 4.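

In this assay, compound 4 gives > 20000 nM, which is a limit of the assay and not a number. With 3-methylphenyl in place of 2-methylphenyl on the amine nitrogen, the result is an at least 1.4-fold higher number from compound 3 to compound 4 (0.14 log units; that floor lies within the scatter), so nothing shows that moving the methyl gives a stronger inhibitor, while a weaker one is not established either. The reading for compound 4 is the only one of its kind in this small set: the limit of > 20000 nM in this assay, at which 1 of the 4 values shown sits.

Open still is how an unsubstituted phenyl, or a methoxy or an amine in place of that methyl, would read on the same amine nitrogen.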